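Ring Size and Amine Position Revisited at the Oxadiazole Carbon

The source may report more compounds than this note shows. Statements on the series, on what has been measured and on what is new or still open speak of the compounds shown alone.

Going by the values given here, compound 2 `CCCCCCCCCCc1ccc(-c2noc(C3CCNC3)n2)cc1` gives 26% in an assay on HeLa cells for inhibition of sphingosine-1-phosphate transporter SPNS2 (Mus musculus), read by LC-MS, tested at 2 uM (a lower number here means less inhibition, a higher number more inhibition at the concentration tested (going by the name of the read-out)), the lower of the two numbers measured so far. Among the compounds with values here, compound 1 `CCCCCCCCCCc1ccc(-c2noc(CCCN)n2)cc1` gives 67% in this assay, and the one known step, a number 41 percentage points lower from compound 1 to compound 2 (beyond the scatter), is the only direct guide to how changes at this position play out. Compound 3 `CCCCCCCCCCc1ccc(-c2noc([C@H]3CCC[C@@H](N)C3)n2)cc1` is the next compound, and it differs from compound 2 as follows: 3-aminocyclohexyl in place of pyrrolidin-3-yl on an aromatic carbon. Within the data shown here, no measured step covers exactly this change. The step from compound 1 to compound 2 shows that swapping a 3-aminopropyl chain for a pyrrolidin-3-yl ring at this carbon cost a large amount of inhibition; compound 3 carries a primary amine again, as compound 1 does, but on a six-membered ring rather than a chain. A partial recovery toward the value of compound 1 is therefore expected, though the uncertainty is wide. Compound 3 is estimated at 48% in this assay, within 18% to 78%, which would mean an expected step of a number 22 percentage points higher from compound 2 to compound 3 (beyond the scatter).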

Compound 3, a percentage reported as inhibition, at one concentration (the size of the read-out at that concentration, not a potency): 29%
For compound 3 the middle estimate is 19 percentage points above the measured one, and the stated range covers the measured number.
By their numbers in this assay, from the lowest: compounds 2 and 3 (each within the scatter of the next); then compound 1.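

In this assay, swapping the pyrrolidin-3-yl ring for the 3-aminocyclohexyl ring gives a number 3 percentage points higher from compound 2 to compound 3 (within the scatter), so at this carbon of the shared core the two rings cannot be told apart, even though one holds its nitrogen inside a five-membered ring and the other carries it on a six-membered ring of carbon only. The comparison with the open chain gives a number 38 percentage points lower from compound 1 to compound 3 (beyond the scatter), which shows that a primary amine on a ring does not match the inhibition seen with the 3-aminopropyl chain. Among these three compounds, then, the chain stands apart from both rings, with no exception so far, but the data at hand offer no explanation for that gap.

Three compounds cannot show whether the chain's length matters, and a 2-aminoethyl or 4-aminobutyl chain in the same place would test that directly. On these data alone, it also remains open whether the other stereoisomers of 3-aminocyclohexyl, or a piperidin-4-yl ring, would behave like compound 3 or move closer to compound 1.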